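This account rests on a few compounds, and the source may have more. Where it says the series, first, only, none or still open, it means among the compounds named here.

Measured compounds:
Compound 1 `COc1ccc(-c2cc(/N=C3/NC(=O)CS3)cs2)cc1` gives > 50000 nM in a functional assay on SW-620 cells (Homo sapiens) for cytotoxicity, read by MTT assay, with a stated time of 72 h (a lower number here means a stronger inhibitor, a higher number a weaker inhibitor), a limit of the assay and not a number.
Compound 2 `O=C1CS/C(=N\c2csc(-c3ccccc3)c2)N1` gives > 50000 nM in this assay, likewise a limit.
Compound 3 `COc1cccc(N2C(=O)CS/C2=N\c2csc(-c3ccc(Cl)cc3)c2)c1` gives 33000 nM in this assay.

The change methoxy in place of hydrogen on an aromatic carbon gives the step that the two limits leave unreadable from compound 2 to compound 1, whose size cannot be read, since both ends sit at the limit of > 50000 nM in this assay, at which 2 of the 3 values shown sit. The difference between the core of compound 3 and the core of compound 2 is not broken down here. For the measured compounds named here, compound 3 carries the only number among the three, and its value stands alone without a readable step to either limit.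

Compound 4 `COc1ccc(N2C(=O)CS/C2=N\c2csc(-c3ccc(Cl)cc3)c2)cc1OC` is not yet measured. It differs from compound 3 by methoxy in place of hydrogen on an aromatic carbon, the same kind of change as from compound 2 to compound 1, but here the place is ortho to a methoxy group rather than bare. Since the earlier step is unreadable, the expected step of a 1.1-fold lower number from compound 3 to compound 4 (0.04 log units; within the scatter) rests only on the value of compound 3, 33000 nM, and is taken as small. Compound 4 is therefore estimated at 30000 nM in this assay, between 10000 nM and 90000 nM.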

Compound 4, half-maximal inhibitory concentration: > 50000 nM
Compound 4: only a limit was reported (the forecaster's own chance of this, stated with the estimate: 30%); middle value at least 1.6-fold (0.22 log units) from the limit.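

In this assay, methoxy in place of hydrogen on an aromatic carbon, ortho to a methoxy group, gives an at least 1.5-fold higher number from compound 3 to compound 4 (0.18 log units; that floor lies within the scatter). Compound 4 gives > 50000 nM, which is a limit of the assay and not a number, so this step has only a floor and does not show a change beyond the scatter. The same kind of change from compound 2 to compound 1 cannot be read, so nothing here shows whether the change carries from one core to the other, either in direction or in size, and only one value in the set is an actual number: the limit of > 50000 nM in this assay, at which 3 of the 4 values shown sit.

The compounds shown leave open whether another group at this place on the ring, such as an amine or a carboxylic acid, would give a value clearly apart from that of compound 3. They also leave open whether a longer chain in place of the methoxy group would give a readable number in this assay.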